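The source may report more compounds than this note shows. Statements on the series, on what has been measured and on what is new or still open speak of the compounds shown alone.

Three members of the series carry the shared core with different end groups: compound 1 `O=C(Nc1ccc(Cl)cc1)Nc1ccc(Oc2ccc(-c3nccs3)cc2)cc1`, compound 2 `O=C(Nc1ccccc1)Nc1ccc(Oc2ccc(-c3nccs3)cc2)cc1` and compound 3 `O=C(Nc1ccccc1)Nc1ccc(Oc2ccc(-c3ncc[nH]3)cc2)cc1`. In a functional assay on MDA-MB-231 cells (Homo sapiens) for inhibition, read by MTT assay and WST assay, with a stated time of 72 h, tested at 10 uM (a lower number here means less inhibition of growth, a higher number more inhibition of growth at the concentration tested), compound 1 gives 32.5%. For compound 2 the entry in this assay reads "not determined" (no result reported), so no number was obtained. Compound 3 gives 11.4% in this assay, which is the lower of the two numbers present; the gap between compound 3 and compound 1 lies beyond the usual scatter of this kind of measurement, and compound 2 stands beside them without a number. Compound 4 `Cc1ccc(NC(=O)Nc2ccc(Oc3ccc(-c4ncc[nH]4)cc3)cc2)cc1` arises from compound 3 by methyl in place of hydrogen on an aromatic carbon. Among the measured compounds shown here, no pair of measured compounds carries this change, so there is nothing against which its size can be read. The expected step is small, a number 3.6 percentage points higher from compound 3 to compound 4 (within the scatter), with no direction secured beyond the scatter. Compound 4 is accordingly estimated at 15% in this assay, within a range from 0% to 35%.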

Compound 4, percent growth inhibition at one concentration: 49.3%
The estimate for compound 4 lay 34.3 percentage points below the measured number; measured number outside the range, above it.
By their numbers in this assay, from the lowest: compound 3; then compound 1; then compound 4.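

In this assay, the change from phenyl to 4-methylphenyl gives a number 37.9 percentage points higher from compound 3 to compound 4 (beyond the scatter). Among the compounds shown here, this is the first one-place step with a number at both ends, and it shows that the aromatic carbon para to a large group is not indifferent to substitution: one added carbon moves growth inhibition beyond the scatter. No measurement at hand bears on what lies behind this step.

The compounds shown leave open whether the rise is particular to methyl or would also appear at this position with a longer chain such as ethyl, with methoxy or with an amine. Also open, going by these compounds, is whether the same change carries over to the other end group, shared by compound 1 and compound 2, as compound 2 stands without a number.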